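Trimming the alkoxy group down to a single fluorine

A few compounds are considered here, and "the series" means these few. Any claim that something is new, unique, unknown or untested is made for them only; others in the source may bear on it.

compound 1 `CCCCOc1ccccc1Cc1cnc(N)nc1N`: 8710 nM
compound 2 `COc1ccccc1Cc1cnc(N)nc1N`: 28800 nM
compound 3 `CCOc1ccccc1Cc1cnc(N)nc1N`: 24500 nM

All three share one core and differ only in the group on the six-membered aromatic ring of carbon only. In an assay for inhibition of Dihydrofolate reductase (Gallus gallus) (a lower number here means a stronger inhibitor, a higher number a weaker inhibitor), compound 3 holds the second highest of the three numbers; compound 2 lies within the scatter of it, while compound 1 stands apart: a 2.8-fold higher number from compound 1 to compound 3 (0.45 log units; beyond the scatter). Compound 4 `Nc1ncc(Cc2ccccc2F)c(N)n1` carries fluoro in place of ethoxy on an aromatic carbon. Among the measured compounds shown here, no measured pair removes the oxygen, so the steps that bear on this are the ones shortening the chain, a 3.3-fold higher number from compound 1 to compound 2 (0.52 log units; beyond the scatter) and a 2.8-fold higher number from compound 1 to compound 3 (0.45 log units; beyond the scatter), both toward weaker inhibition as the group shrinks, whereas a 1.2-fold lower number from compound 2 to compound 3 (0.07 log units; within the scatter). Compound 4 is therefore expected to show a small rise or none beyond the scatter, a 1.4-fold higher number from compound 3 to compound 4 (0.15 log units; within the scatter). Compound 4 is estimated at 35000 nM, within 12000 nM to 100000 nM.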

Compound 4, inhibition constant: 43700 nM
Estimate against measurement, compound 4: 1.2-fold (0.10 log units) below; measured number inside the range.
By their numbers in this assay, from the lowest: compound 1; then compounds 3, 2 and 4 (each within the scatter of the next).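

In this assay fluoro leaves compound 4 level with the two short alkoxy compounds, with a 1.8-fold higher number from compound 3 to compound 4 (0.25 log units; within the scatter) and a 1.5-fold higher number from compound 2 to compound 4 (0.18 log units; within the scatter) as the steps, so at this aromatic carbon losing the oxygen along with its chain moves the number no further than the scatter. Among the compounds shown here, only the butoxy group stands apart from fluoro, with a 5.0-fold higher number from compound 1 to compound 4 (0.70 log units; beyond the scatter) as the one step beyond the scatter. No measurement given here explains these numbers. On these data alone, whether a butyl chain without the oxygen would match compound 1 stays open. So does how an amine or a chlorine would compare at this place.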